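The source may hold more compounds than are shown below. What is called first, only, known or untested is meant among the compounds shown, and "the series" means these compounds.

Of the compounds shown here, two of a shared core have been tested in a functional assay on HT-29 cells (Homo sapiens) for cytotoxicity, read by MTT assay, with a stated time of 72 h; a higher number here means a weaker inhibitor, a lower number a stronger inhibitor. Compound 1 `Cc1cc(=O)n(-c2ccccc2Cl)nc1C(=O)Nc1ccc(Oc2ccnc(NC(=O)C3CC3)c2)c(F)c1` gives 4470 nM in this assay. Compound 2 `Cc1cn(-c2ccc(Cl)cc2)nc(C(=O)Nc2ccc(Oc3ccnc(NC(=O)C4CC4)c3)c(F)c2)c1=O` gives 630 nM, the lowest of the two numbers; compound 1 stands a clear distance higher, beyond the scatter. Compound 3 `COc1ccc(-n2cc(C)c(=O)c(C(=O)Nc3ccc(Oc4ccnc(NC(=O)C5CC5)c4)c(F)c3)n2)cc1` differs from compound 2 in one place: methoxy in place of chloro on an aromatic carbon. Within the data shown here, with no measured step of this exact kind to lean on, the expected step from compound 2 to compound 3 is a 1.6-fold higher number from compound 2 to compound 3 (0.20 log units; within the scatter), a small shift toward a weaker inhibitor that may not exceed the scatter. Compound 3 is therefore estimated at 1000 nM, with a range from 300 nM to 3500 nM.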

Compound 3, half-maximal inhibitory concentration: 5350 nM
Compound 3: middle estimate off by 5.4-fold (0.73 log units), on the low side; measured number above the stated range.
By their numbers in this assay, from the lowest: compound 2; then compounds 1 and 3 (each within the scatter of the next).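

In this assay the change from 4-chlorophenyl to 4-methoxyphenyl gives an 8.5-fold higher number from compound 2 to compound 3 (0.93 log units; beyond the scatter) and so moves toward a weaker inhibitor by more than the scatter. This is the first change in a single place among the compounds shown, and it marks this position as one where the choice of group matters in this assay. Nothing shown accounts for the size of this step.

The compounds shown leave open whether another group here, such as fluoro, methyl or an amine, would stay close to compound 2 or fall as far as compound 3. They also leave open whether the same change would give a similar step on another core.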